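This account rests on a few compounds, and the source may have more. Where it says the series, first, only, none or still open, it means among the compounds named here.

Working notes on a small deoxynucleoside series tested in a functional assay on HL-60 cells (Homo sapiens); a higher number here means a weaker inhibitor, a lower number a stronger inhibitor.

Compound 1, `CN(C)c1nc(N)c2ncn([C@@H]3C[C@@H](O)[C@H](CO)O3)c2n1`, carries an amino group and a dimethylamino group on the shared core. In this assay compound 1 gives > 300 uM, which is a limit of the assay and not a number.

Compound 2, `CN(C)c1nc(Br)nc2c1ncn2[C@@H]1C[C@@H](O)[C@H](CO)O1`, carries a bromo group and a dimethylamino group on the same core. In this assay compound 2 gives > 300 uM, again a limit of the assay rather than a measured number. Compound 2 therefore stands at the limit of > 300 uM in this assay, at which 2 of the 2 values shown sit, and no ordering of compound 1 and compound 2 can be read from these two limits.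

Compound 3, `Nc1nc(Br)nc2c1ncn2[C@@H]1C[C@@H](O)[C@H](CO)O1`, is not yet measured. It differs from compound 2 by amino in place of dimethylamino on an aromatic carbon. Among the measured compounds shown here, no measured step between the compounds exists, so no size of effect can be drawn from the data. Starting from a limit, the step from compound 2 to compound 3 is expected to be a number no higher from compound 2 to compound 3 (the limit leaves the size open), with a further limit the most likely outcome. For compound 3 the expected value in this assay is 300 uM, with a range from 60 uM to 1500 uM.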

Compound 3, concentration for 50% inhibition: 41 uM
For compound 3 the middle estimate is 7.3-fold (0.86 log units) above the measured one; measured number outside the range, below it.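

Compound 3 gives the series its first number rather than a limit in this assay, so activity on the shared core can now be measured. On this aromatic carbon, amino in place of dimethylamino with the bromo group kept gives an at least 7.3-fold lower number from compound 2 to compound 3 (0.86 log units; beyond the scatter), and bromo in place of dimethylamino with the amino group kept gives an at least 7.3-fold lower number from compound 1 to compound 3 (0.86 log units; beyond the scatter). Of the three compounds, only compound 3 carries no dimethylamino group, and only compound 3 gives a number.

As far as these compounds go, the true size of both steps stays open, as each starts from a limit: the limit of > 300 uM in this assay, at which 2 of the 3 values shown sit. Also open, from the compounds shown here alone, is whether a single methylamino group on this carbon, or a chloro group in place of the bromo group, would keep the number seen for compound 3.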